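Amide variation on the shared core: removal of one chloro

The source may report more compounds than this note shows. Statements on the series, on what has been measured and on what is new or still open speak of the compounds shown alone.

Compound 3 `O=C(Nc1ccc(Cl)c(-c2nnc3c(Cl)cccn23)c1)c1ccc(Cl)cc1Cl` gives 84800 nM in a functional assay on AN3-CA cells (Homo sapiens) for antiproliferative activity, read by MTT assay, with a stated time of 72 h (on this read-out higher numbers stand for weaker inhibition and lower numbers for stronger inhibition), the highest of the two numbers in hand. Compound 1 `O=C(Nc1ccc(Cl)c(-c2nnc3c(Cl)cccn23)c1)c1ccc(C(F)(F)F)cc1F` gives 41200 nM, a lower number beyond the scatter. Compound 2 `CS(=O)(=O)c1ccc(C(=O)Nc2ccc(Cl)c(-c3nnc4c(Cl)cccn34)c2)cc1` gives only a limit, > 100000 nM, and so stands outside any ordering. Within the data shown here, the one measured step, an at least 1.1-fold lower number from compound 2 to compound 3 (0.07 log units; that floor lies within the scatter), rests on that limit of > 100000 nM in this assay, at which 1 of the 3 values shown sits, and says little more than that the dichlorophenyl amide is not weaker than the methylsulfonyl amide.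

Compound 4 `O=C(Nc1ccc(Cl)c(-c2nnc3c(Cl)cccn23)c1)c1ccccc1Cl` differs from compound 3 by hydrogen in place of chloro on an aromatic carbon, that is, 2,4-dichlorophenyl to 2-chlorophenyl on the carbonyl carbon. Among the measured compounds shown here, no measured step removes a single chloro on the amide aryl ring, so nothing in hand bears directly on this change; all amide variations so far stay in the weak range or at the limit. The step from compound 3 to compound 4 is therefore expected to be small, a 1.1-fold higher number from compound 3 to compound 4 (0.03 log units; within the scatter), with no confident direction. Compound 4 is estimated at 90000 nM, between 40000 nM and 200000 nM.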

Compound 4, half-maximal inhibitory concentration: > 100000 nM
Compound 4: only a limit was reported; the forecaster's own chance of this, stated with the estimate: 40%; at least 1.1-fold (0.04 log units) between middle value and limit.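

Going from 2,4-dichlorophenyl to 2-chlorophenyl on the carbonyl carbon gives an at least 1.1-fold higher number from compound 3 to compound 4 (0.07 log units; that floor lies within the scatter), so hydrogen in place of this chloro, para to a large group, brings no gain, while the true size of the step remains unknown. In this assay compound 4 gives only a limit, > 100000 nM. The step between compound 2 and compound 4 cannot be read, and the upper end of the read-out now holds more of this small set: the limit of > 100000 nM in this assay, at which 2 of the 4 values shown sit.

Open, as far as these compounds go, is whether an amine or a carboxylic acid on the amide aryl ring would bring the number well clear of this weak range. Also open, from the compounds shown here alone, is whether a fluoro or methoxy group in place of this chloro would give a value that is a number rather than a limit.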